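Side-chain change on the shared core: compound 1 to compound 3

A few compounds are considered here, and "the series" means these few. Any claim that something is new, unique, unknown or untested is made for them only; others in the source may bear on it.

Measured so far:
- compound 1, `Nc1nc(O)c2c(n1)n(C1OC(CO)[C@@H](O)[C@H]1O)c(=O)n2Cc1ccc(Cl)c(Cl)c1`, in a functional assay on the whole organism with Mus musculus as the target (on this read-out lower numbers stand for smaller maximal responses and higher numbers for larger maximal responses), compound 1 gives 0%
- compound 2, `CCCn1c(=O)n(C2OC(COP(=O)(O)O)[C@@H](O)[C@H]2O)c2nc(N)nc(O)c21`, in this assay compound 2 gives 57%

Compound 1 stands lowest of the two numbers; the nearest is compound 2, whose value lies higher by a margin beyond the scatter. Going by the values given here, compound 2 differs from compound 1 in more than one place, so no single step between them is defined, and the two values are taken only as they stand.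

The step of interest goes from compound 1 to compound 3, `CCOC(=O)Cn1c(=O)n(C2OC(CO)[C@@H](O)[C@H]2O)c2nc(N)nc(O)c21`. The change is ethoxycarbonyl in place of 3,4-dichlorophenyl on a saturated chain carbon bound to an aromatic nitrogen. Nothing measured isolates this change, so its size is open. The reference point is compound 1 with 0% in this assay, and compound 2 shows that a smaller chain on the same nitrogen can coincide with a large response. A moderate rise is expected, with wide uncertainty: for compound 3 the estimated step is a number 20 percentage points higher from compound 1 to compound 3 (beyond the scatter), and the expected value is 20%, within 0% to 55%.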

Compound 3, largest response reached (reported as maximal response), in percent of the reference or control that the assay uses: 58%
Compound 3: middle estimate off by 38 percentage points, on the low side; measured number above the stated range.
By their numbers in this assay, from the lowest: compound 1; then compounds 2 and 3 (each within the scatter of the next).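

In this assay, ethoxycarbonyl in place of 3,4-dichlorophenyl on a saturated chain carbon bound to an aromatic nitrogen gives a number 58 percentage points higher from compound 1 to compound 3 (beyond the scatter). Going by these compounds alone, this is the first single change read, and it shows that the response depends strongly on this group: the rest of the molecule is unchanged, so the shared core with this side chain is not silent in itself, and the low number of compound 1 goes with the 3,4-dichlorobenzyl group. Nothing at hand explains why the step is this large.

From the compounds shown here alone, the step removes an aromatic ring and brings in an ester at once, so it remains open which of the two carries the change. An unsubstituted phenyl or a carboxylic acid in the same place would separate them.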